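Methoxy in Place of Bromo: From Compound 3 to Compound 4

The source may report more compounds than this note shows. Statements on the series, on what has been measured and on what is new or still open speak of the compounds shown alone.

Within the data shown here, in a functional assay on MKN-74 cells (Homo sapiens) for antiproliferative activity, with a stated time of 24 h (on this read-out higher numbers stand for weaker inhibition and lower numbers for stronger inhibition), compound 3 `NC(=O)c1c(NC(=O)c2ccccc2Br)sc2c1CCN(C(=S)Nc1ccccc1Cl)C2` gives 12900 nM, the lowest of the three numbers so far. Compound 1 `NC(=O)c1c(NC(=O)c2ccccc2Cl)sc2c1CCN(Cc1ccc(Cl)cc1)C2` gives 18700 nM, a gap from compound 3 that lies within the scatter. Compound 2 `NC(=O)c1c(NC(=O)c2ccc(C(F)(F)F)cc2)sc2c1CCN(Cc1ccccc1F)C2` gives 26900 nM, a gap from compound 3 that lies beyond the scatter. Among the measured compounds shown here, no two of these three compounds differ in a single place, so no measured step stands behind any expectation. Compound 4 `COc1ccccc1C(=O)Nc1sc2c(c1C(N)=O)CCN(C(=S)Nc1ccccc1Cl)C2` differs from compound 3 by methoxy in place of bromo on an aromatic carbon, a methoxy in place of bromo on an aromatic carbon. With nothing comparable measured, the change from compound 3 is expected to be a 1.2-fold higher number from compound 3 to compound 4 (0.07 log units; within the scatter), not beyond the scatter in either direction. Compound 4 is therefore estimated at 15000 nM, within 6000 nM to 40000 nM.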

Compound 4, half-maximal inhibitory concentration: 20500 nM
Compound 4: the middle estimate sits 1.4-fold (0.14 log units) below what was measured, within the range that was stated.
By their numbers in this assay, from the lowest: compounds 3, 1, 4 and 2 (each within the scatter of the next, the first and the last beyond it).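

In this assay, methoxy in place of bromo, on an aromatic carbon ortho to a large group, gives a 1.6-fold higher number from compound 3 to compound 4 (0.20 log units; within the scatter). Among these compounds, this is the first single-place step in the set, and it shows that this exchange at this position, with one heavy atom leaving and two entering, stays within the scatter. Nothing available explains this outcome.

Going by these compounds, whether an amine, a carboxylic acid or a longer chain such as ethoxy at this position would go beyond the scatter remains open. So does whether methoxy in place of bromo would read the same in another compound of the set.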